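The compounds below may be only part of what the source reports. "The series", "measured", "known", "first", "only" and "open" are said of these compounds alone.

Of the compounds shown here, three have been measured so far. Compound 1 `COc1c(C)cnc(C[S+]([O-])c2nnc(-c3ccccc3)o2)c1C` gives 6000 nM in a functional assay on HUVEC cells (Homo sapiens) for inhibition, read by ELISA; a higher number here means a weaker inhibitor, a lower number a stronger inhibitor. Compound 2 `[O-][S+](Cc1ccccc1)c1nnc(-c2ccccn2)o1` gives 4000 nM in this assay, and compound 3 `[O-][S+](Cc1ccccc1)c1nnc(-c2cccs2)o1` gives 6000 nM. Compound 1 thus stands at the same digits as compound 3, and its gap to compound 2 is within the scatter, so the three numbers cannot be told apart from one another.

The unmeasured compound 4 `COc1c(C)cnc(C[S+]([O-])c2nnc(-c3cccc(F)c3)o2)c1C` differs from compound 1 in one place: fluoro in place of hydrogen on an aromatic carbon. Among the compounds with values here, no measured step involves this kind of change. Within the data shown here, the only step available, a 1.5-fold higher number from compound 2 to compound 3 (0.18 log units; within the scatter), exchanges one aromatic ring for another in a different part of the molecule and stays within the scatter, so it offers no guidance on adding a fluorine. Without a comparable step, the expectation is that compound 4 stays close to compound 1. A step of no change at the digits printed from compound 1 to compound 4 (within the scatter) is therefore expected, that is, no change beyond the scatter. Compound 4 is expected to give 6000 nM in this assay, within a range from 3000 nM to 12000 nM.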

Compound 4, half-maximal inhibitory concentration: 12000 nM
Compound 4: middle estimate off by 2.0-fold (0.30 log units), on the low side; the measured number falls inside the stated range.
By their numbers in this assay, from the lowest: compounds 2, 1, 3 and 4 (each within the scatter of the next, the first and the last beyond it).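

Fluoro in place of hydrogen, on an aromatic carbon of a six-membered aromatic ring of carbon only and meta to a large group, gives a 2.0-fold higher number from compound 1 to compound 4 (0.30 log units; within the scatter) in this assay. Within the data shown here, this is the first step that reads a change on this ring directly, and a single fluorine here does not move the number beyond what repeated measurements would scatter. No measurement here offers an explanation for the step.

The compounds shown leave open whether a different group at this place, such as a methoxy group, a trifluoromethyl group or an amine, would give a step beyond the scatter. Also open, from the compounds shown here alone, is whether fluoro on another carbon of this ring would read the same way.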